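The compounds below may be only part of what the source reports. "The series", "measured", "known", "first", "only" and "open" are said of these compounds alone.

In a functional assay with Oryctolagus cuniculus as the target (a lower number here means a stronger inhibitor, a higher number a weaker inhibitor), compound 1 `COc1ccc(-c2nc(/N=C(\N)[N+]3(C)CCCCC3)sc2-c2ccc(OC)cc2)cc1` gives > 1000 nM, and this value is a limit. Compound 2 `COc1ccc(-c2nc(CN)sc2-c2ccc(OC)cc2)cc1` gives > 100 nM, which is also a limit. Compound 3 `CCN(CC)C(=O)c1nc(-c2ccc(OC)cc2)c(-c2ccc(OC)cc2)s1` gives < 10 nM, again a limit. On the numbers shown, compound 3 stands lowest of the three.

Compound 4 `COc1ccc(-c2nc(C(=O)N3CCOCC3)sc2-c2ccc(OC)cc2)cc1` has not yet been measured, and its difference from compound 3 is this: morpholin-4-yl in place of diethylamino on a carbonyl carbon. Among the measured compounds shown here, two measured steps bear on it: an at least 100-fold lower number from compound 1 to compound 3 (2.00 log units; beyond the scatter) and an at least 10-fold lower number from compound 2 to compound 3 (1.00 log units; beyond the scatter). Both lie beyond the scatter, the first large and the second at least modest, and both end at the diethylcarbamoyl group. Compound 4 keeps the carbonyl on the aromatic carbon, so these steps suggest that it should stay in the low range. Neither step replaces diethylamino on a carbonyl carbon, so the size of the new step remains uncertain. A modest rise in the number is expected, with the expected step being an at least 1.5-fold higher number from compound 3 to compound 4 (0.17 log units; that floor lies within the scatter). For compound 4, the estimate is 15 nM, with an expected range from 3 nM to 80 nM.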

Compound 4, half-maximal inhibitory concentration: < 10 nM
Compound 4 gave a limit, no number (the forecaster's own chance of this, stated with the estimate: 50%); at least 1.5-fold (0.17 log units) between middle value and limit.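

Replacing diethylamino with morpholin-4-yl on the carbonyl carbon leaves compound 4 at the same limit as compound 3, so this place accepts a six-membered ring carrying a hydrogen-bond acceptor as well as an open diethyl group, as far as that limit can tell, but the step between the two cannot be read: the limit of < 10 nM in this assay, at which 2 of the 4 values shown sit.

The new ring amide also keeps the distance from the other two groups at this place: this assay shows an at least 10-fold lower number from compound 2 to compound 4 (1.00 log units; beyond the scatter) and an at least 100-fold lower number from compound 1 to compound 4 (2.00 log units; beyond the scatter).

As far as these compounds go, how far under that shared limit compound 3 and compound 4 each lie stays open, so any real difference between the two groups remains unknown. Also open, from the compounds shown here alone, is whether dimethylamino on the carbonyl carbon, or a carboxylic acid in place of the whole amide, would reach the same limit.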